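This account rests on a few compounds, and the source may have more. Where it says the series, first, only, none or still open, it means among the compounds named here.

Compound 1 `CN/C(=N\C#N)NCCCSc1nc(N)n[nH]1` is the parent of this short series. In a functional assay on Sf9 cells for antagonist activity at histamine H2 receptor (Homo sapiens), read by scintillation counting and GTPgammaS binding, with a stated time of 90 min (on this read-out higher numbers stand for higher potency (the scale is a negative logarithm) and lower numbers for lower potency), compound 1 gives < 5, a limit of the assay rather than a number. Within the data shown here, compound 2 `N#C/N=C(/NCCCSc1nc(N)n[nH]1)NCCSc1ccccc1` is the first extension of the chain. In this assay compound 2 gives < 5, again a limit and not a number. The step that the two limits leave unreadable from compound 1 to compound 2 is therefore unreadable, since both values sit at the limit of < 5 in this assay, at which 2 of the 2 values shown sit.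

Compound 3 `N#C/N=C(/NCCCCNc1ccccn1)NCCSc1ccccc1` differs from compound 2 by ((pyridin-2-yl)amino)methyl in place of (3-amino-1H-1,2,4-triazol-5-yl)sulfanyl on a saturated chain carbon, three bonds along the chain from an amine nitrogen. No measured step bears on this change: the only step shown, a step that the two limits leave unreadable from compound 1 to compound 2, gives no size in either direction, so the evidence here is only that compound 2 does not rise above its limit. The step of a number at least 0.50 log units higher from compound 2 to compound 3 (beyond the scatter) is thus an estimate resting on that limit alone, expected to be modest and upward if anything. For compound 3 the expected value in this assay is 5.5, with a range from 4.5 to 6.5.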

Compound 3, negative logarithm of the antagonist equilibrium constant: < 5
Compound 3: a limit, no number (the forecaster's own chance of this, stated with the estimate: 45%); at least 0.50 log units between middle value and limit.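

In this assay compound 3 gives < 5, again a limit and not a number, so the step from compound 2 to compound 3 cannot be read: the limit of < 5 in this assay, at which 3 of the 3 values shown sit.

The compounds shown leave open how large either change is, and what number compound 1, compound 2 or compound 3 would actually reach.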